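Ethoxycarbonyl in place of chloro on compound 1

The source may report more compounds than this note shows. Statements on the series, on what has been measured and on what is new or still open speak of the compounds shown alone.

In a functional assay on A549 cells (Homo sapiens) for inhibition, read by CCK-8 assay, with a stated time of 48 h (on this read-out higher numbers stand for weaker inhibition and lower numbers for stronger inhibition), compound 1 (`COc1cc(-c2ccnc3cc(-c4ccc(Cl)cc4)nn23)cc(OC)c1OC`) gives 3070 nM as the highest of three numbers. Compound 2 (`COc1cc(-c2ccnc3cc(-c4ccc5cc[nH]c5c4)nn23)cc(OC)c1OC`) gives 170 nM and compound 3 (`COc1cc(-c2ccnc3cc(-c4ccc5cnn(C)c5c4)nn23)cc(OC)c1OC`) gives 233 nM within the scatter of each other. Compound 4 (`CCOC(=O)c1ccc(-c2cc3nccc(-c4cc(OC)c(OC)c(OC)c4)n3n2)cc1`) has ethoxycarbonyl in place of chloro on an aromatic carbon, para to a large group (ethoxycarbonyl in place of chloro on an aromatic carbon). For the measured compounds named here, two measured steps bear on this only indirectly (an 18-fold lower number from compound 1 to compound 2 (1.26 log units; beyond the scatter) and a 13-fold lower number from compound 1 to compound 3 (1.12 log units; beyond the scatter)): both are large, yet each replaces the whole 4-chlorophenyl, and no measured step changes this one place alone. No step beyond the scatter is therefore expected in this assay in either direction, and the estimated change is small (a 1.2-fold lower number from compound 1 to compound 4 (0.09 log units; within the scatter)). For compound 4 the estimate is 2500 nM (expected range 800 nM to 7500 nM).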

Compound 4, half-maximal inhibitory concentration: > 10000 nM
Compound 4 ended at the assay's limit; the forecaster's own chance of this, stated with the estimate: 8%; middle value at least 4.0-fold (0.60 log units) from the limit.
By their numbers in this assay, from the lowest: compounds 2 and 3 (each within the scatter of the next); then compound 1. At a limit, above all of these: compound 4.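

Changing this one place alone, with ethoxycarbonyl in place of chloro, gives in this assay an at least 3.2-fold higher number from compound 1 to compound 4 (0.51 log units; beyond the scatter), so this aromatic carbon is not indifferent to the group it carries. The earlier steps shown here replaced the whole 4-chlorophenyl, whereas here the six-membered ring stays and only its substituent changes. The result for compound 4 is a limit and not a number: the limit of > 10000 nM in this assay, at which 1 of the 4 values shown sits.

The compounds shown leave open whether a carboxylic acid, a methyl ester or an amide at this place would give a number nearer that of compound 1. They also leave open whether an amine there would lower the number.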